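A few compounds are considered here, and "the series" means these few. Any claim that something is new, unique, unknown or untested is made for them only; others in the source may bear on it.

Series notes. Compound 1 `C/C(CN)=C(/F)CN(C[C@H]1Cc2ccccc2CN1)[C@H]1CCCc2cccnc21` gives 44 nM in a functional assay on CCRF-CEM cells for antagonist activity at C-X-C chemokine receptor type 4 (Homo sapiens), read by calcium flux, with stated times of 25 min and 90 s; on this read-out lower numbers stand for stronger inhibition and higher numbers for weaker inhibition. Compound 2 `C/C(=C/CN(C[C@H]1Cc2ccccc2CN1)[C@H]1CCCc2cccnc21)CN` gives 8.6 nM in this assay, and a 5.1-fold lower number from compound 1 to compound 2 (0.71 log units; beyond the scatter). Compound 3 `NC(=O)NC/C=C\CN(C[C@H]1Cc2ccccc2CN1)[C@H]1CCCc2cccnc21` gives 210 nM, the highest number of the three; a 4.8-fold higher number from compound 1 to compound 3 (0.68 log units; beyond the scatter), and a 24-fold higher number from compound 2 to compound 3 (1.39 log units; beyond the scatter). Compound 4 `N[C@H]1CC[C@@H](N(C[C@H]2Cc3ccccc3CN2)[C@H]2CCCc3cccnc32)CC1` is not yet measured. The change from compound 3 to compound 4: a group of 7 heavy atoms (6 carbon, 1 nitrogen; one six-membered non-aromatic ring of carbon only) in place of a group of 8 heavy atoms (5 carbon, 2 nitrogen, 1 oxygen; no ring), on an amine nitrogen. Going by the values given here, no measured step exchanges a chain for a ring, so the bearing is indirect: the large step from compound 2 to compound 3 came with the chain of compound 3 replacing the chain of compound 2, and compound 4 again carries a 4-aminocyclohexyl group with its hydrogen-bond donor. A lower number for compound 4 is therefore expected, an 8.4-fold lower number from compound 3 to compound 4 (0.92 log units; beyond the scatter), with wide uncertainty. Compound 4 is estimated at 25 nM, range 5 nM to 150 nM.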

Compound 4, half-maximal inhibitory concentration: 1800 nM
Estimate against measurement, compound 4: 72-fold (1.86 log units) below; the measured number lies above the stated range.
By their numbers in this assay, from the lowest: compound 2; then compound 1; then compound 3; then compound 4.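

In this assay the 4-aminocyclohexyl group on the amine nitrogen gives the weakest inhibition of the four, with a 210-fold higher number from compound 2 to compound 4 (2.32 log units; beyond the scatter) and a 41-fold higher number from compound 1 to compound 4 (1.61 log units; beyond the scatter) and also an 8.6-fold higher number from compound 3 to compound 4 (0.93 log units; beyond the scatter) in this series. An amine on the group is therefore not enough at this position: the ring with its amine reads above the amine-bearing chains of compound 1 and compound 2, and also above the chain of compound 3, which has no such amine. On these data alone, whether a 4-(aminomethyl)cyclohexyl group or a piperidine would recover the values of those chains remains open. The data at hand give no account of this loss.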